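The source may report more compounds than this note shows. Statements on the series, on what has been measured and on what is new or still open speak of the compounds shown alone.

Among the measured compounds shown here, compound 2 `C[C@H]1[C@H](N)CN1c1nc2c(cc1F)c(=O)c(C(=O)O)cn2C1CC1` gives 16.5 ug/mL in a physicochemical assay for solubility, at pH 7.4 (on this read-out lower numbers stand for lower solubility and higher numbers for higher solubility), and this is the only true number so far. Compound 1 `C[C@H](N)C(=O)N[C@@H]1CN(c2nc3c(cc2F)c(=O)c(C(=O)O)cn3C2CC2)[C@H]1C` gives > 500 ug/mL in this assay, which is a limit of the assay and not a number.

Compound 3 `C[C@H](N)C(=O)N[C@@H](C)C(=O)N[C@@H]1CN(c2nc3c(cc2F)c(=O)c(C(=O)O)cn3C2CC2)[C@H]1C` is compound 2 with one change, ((1-(((1-aminoethyl)carbonyl)amino)ethyl)carbonyl in place of hydrogen on an amine nitrogen). In words, (1-(((1-aminoethyl)carbonyl)amino)ethyl)carbonyl stands in place of hydrogen on an amine nitrogen.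

For the measured compounds named here, one measured step bears on this change: an at least 30-fold lower number from compound 1 to compound 2 (1.48 log units; beyond the scatter). That step had hydrogen in place of (1-aminoethyl)carbonyl on an amine nitrogen, on the same nitrogen and the same core, and it was large. The group entering compound 3 contains (1-aminoethyl)carbonyl within its longer chain, so the change runs in the opposite sense to that step. Going by the values given here, no measured compound carries the longer chain itself, which leaves the size uncertain.

A large move to a higher number is therefore expected in this assay. The expected change is a 42-fold higher number from compound 2 to compound 3 (1.63 log units; beyond the scatter). Compound 3 may also end at the limit of > 500 ug/mL in this assay, at which 1 of the 2 values shown sits. For compound 3 the estimated value is 700 ug/mL, with an expected range of 150 ug/mL to 3000 ug/mL.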

Compound 3, solubility: > 500 ug/mL
Compound 3 ended at the assay's limit (the forecaster's own chance of this, stated with the estimate: 65%); the middle value does not contradict the limit.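

On the amine nitrogen whose other neighbours are saturated ring carbon, (1-(((1-aminoethyl)carbonyl)amino)ethyl)carbonyl in place of hydrogen gives an at least 30-fold higher number from compound 2 to compound 3 (1.48 log units; beyond the scatter) in this assay. The earlier compounds shown here showed a large move on this nitrogen only for (1-aminoethyl)carbonyl, and this step shows that a move of that large size is not confined to that one group, since the longer chain also produces it on the same core. Compound 1 and compound 3 both end at a limit of the assay and not at a number, and the step between them cannot be read: the limit of > 500 ug/mL in this assay, at which 2 of the 3 values shown sit.

From the compounds shown here alone, whether the longer chain carries the number further than the shorter group therefore stays open, and so does how far past the limit either compound lies. Also open, going by these compounds, is whether the amine at the end of these chains is needed for the move, which a carbonyl group without an amine on this nitrogen would test, and whether a chain with a carboxylic acid in place of that amine would behave the same way.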